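A few compounds are considered here, and "the series" means these few. Any claim that something is new, unique, unknown or untested is made for them only; others in the source may bear on it.

Of the compounds shown here, three have so far been measured in a functional assay on HeLa cells (Homo sapiens) for inhibition, read by CCK-8 assay, with a stated time of 72 h, tested at 2 uM; a higher number here means more inhibition of growth at the concentration tested, a lower number less inhibition of growth. Compound 1 `COc1ccc(SCc2ccc(/C=C/C(=O)Nc3ccccc3N)cc2)cc1OC` gives 10.1%, compound 2 `Nc1ccccc1NC(=O)c1ccc(CSc2nccc(C(F)(F)F)n2)cc1` gives 68.3%, and compound 3 `Cc1ccc(SCc2ccc(C(=O)Nc3ccccc3N)cc2)cc1` gives 33.8%. Compound 3 thus stands second among the three: the number nearest to it belongs to compound 1, which lies lower by a gap beyond the usual scatter, and the number furthest from it belongs to compound 2, which lies higher, again beyond the scatter. Among the measured compounds shown here, no two of these measured compounds differ in only one place, so no single step between them can be read off.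

Compound 4 `Nc1ccccc1NC(=O)c1ccc(CSc2ccc(F)cc2)cc1` awaits measurement in this assay. It differs from compound 3 by fluoro in place of methyl on an aromatic carbon. One heavy atom leaves and one heavy atom enters at the same place, with no ring and no donor or acceptor involved. Because compound 3 gives 33.8% and nothing measured shows fluoro in place of methyl, the estimated step is a number 3.2 percentage points higher from compound 3 to compound 4 (within the scatter), expected to be none beyond the scatter. Compound 4 is estimated at 37%, with a range from 20% to 56%.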

Compound 4, percent growth inhibition at one concentration: 27.9%
Compound 4: the middle estimate sits 9.1 percentage points above what was measured; the measured number falls inside the stated range.
By their numbers in this assay, from the lowest: compound 1; then compounds 4 and 3 (each within the scatter of the next); then compound 2.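

In this assay, among the compounds shown here, the exchange of fluoro for methyl on an aromatic carbon, para to a large group, gives the first step that can be read between two compounds differing in one place: a number 5.9 percentage points lower from compound 3 to compound 4 (within the scatter). At this position, then, 4-methylphenyl and 4-fluorophenyl give numbers that cannot be told apart at the single concentration tested, so this exchange alone moves the number by no more than the usual scatter. No measurement at hand bears on why the two compounds read alike.

A single exchange of two small groups leaves open whether a methoxy group, an amine or a carboxylic acid at this same place would move the number beyond the scatter. It also leaves open whether fluoro in place of methyl would read the same way elsewhere on this ring.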